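Three Measured Analogues and an Unmeasured Nitro Compound

A few compounds are considered here, and "the series" means these few. Any claim that something is new, unique, unknown or untested is made for them only; others in the source may bear on it.

Measured in a functional assay on RL cells (Homo sapiens) for cytotoxicity, with a stated time of 48 h; a lower number here means a stronger inhibitor, a higher number a weaker inhibitor:
Compound 1, `COc1cc(OC)c(C(=O)/C=C/c2ccc(Cl)cc2)c(OC)c1`, gives 6500 nM.
Compound 2, `COc1cc(OC)c(C(=O)/C=C/c2ccc(Br)cc2)c(OC)c1`, gives 8300 nM.
Compound 3, `COc1cc(OC)c(C(=O)/C=C/c2ccccc2)c(OC)c1`, gives 6900 nM.

Compound 3 stands second highest of the three numbers, nearest to compound 1 and furthest from compound 2, and all three lie within the scatter of one another.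

Compound 4, `COc1cc(OC)c(C(=O)/C=C/c2ccc([N+](=O)[O-])cc2)c(OC)c1`, differs from compound 3 by nitro in place of hydrogen on an aromatic carbon. Within the data shown here, the steps that bear on this are a 1.1-fold higher number from compound 1 to compound 3 (0.03 log units; within the scatter) and a 1.2-fold lower number from compound 2 to compound 3 (0.08 log units; within the scatter), both within the scatter; neither involves a nitro group, so the data carry no direct guidance. Compound 4 is therefore expected to show a 1.0-fold higher number from compound 3 to compound 4 (0.01 log units; within the scatter), nothing beyond the scatter. The estimate for compound 4 is 7000 nM, with a range from 2500 nM to 20000 nM.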

Compound 4, half-maximal inhibitory concentration: 3400 nM
Compound 4: the middle estimate sits 2.1-fold (0.31 log units) above what was measured; measured number inside the range.
By their numbers in this assay, from the lowest: compounds 4, 1, 3 and 2 (each within the scatter of the next, the first and the last beyond it).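

In this assay, among these compounds, nitro on this aromatic carbon, para to a large group, gives a 2.0-fold lower number from compound 3 to compound 4 (0.31 log units; beyond the scatter) and is the first change at this position to pass the scatter, as chloro and bromo stayed within it of hydrogen. In place of bromo it gives a 2.4-fold lower number from compound 2 to compound 4 (0.39 log units; beyond the scatter) and in place of chloro a 1.9-fold lower number from compound 1 to compound 4 (0.28 log units; within the scatter) so compound 4 is not set apart from both halogen compounds. Nothing in the available data accounts for this step.

The compounds shown leave open whether an amine or a carboxylic acid at this position would give a similar step. They also leave open whether the nitro step would hold on a different core.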